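A few compounds are considered here, and "the series" means these few. Any claim that something is new, unique, unknown or untested is made for them only; others in the source may bear on it.

Compound 1 `CCC(C)C1NC(=O)N(C2CCCC2)C1=O` is tolerated in a functional assay on HEL cells (Homo sapiens) for cytotoxicity (a higher number here means that more compound is tolerated, a lower number that less compound is tolerated), up to the limit of the test, > 100 ug/mL.
Compound 2 `CC(C)C1NC(=O)N(C2CCCC2)C1=O` likewise reaches only a limit in this assay, > 100 ug/mL.
Compound 3 `CC(C)C(NC(=O)n1nnc2ccccc21)C(=O)NC1CCCC1` sits at a limit as well in this assay, > 200 ug/mL.

Compound 2 and compound 1 differ by methyl in place of hydrogen on a saturated chain carbon, two bonds along the chain from a saturated ring carbon. The resulting step, a step that the two limits leave unreadable from compound 2 to compound 1, cannot be sized, as both compounds stand at the limit of > 100 ug/mL in this assay, at which 2 of the 3 values shown sit. How the core of compound 3 differs from that of compound 2 is not broken down here; compound 3 stands at the limit of > 200 ug/mL in this assay, at which 1 of the 3 values shown sits.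

Compound 4 `CCC(C)C(NC(=O)n1nnc2ccccc21)C(=O)NC1CCCC1` has not been tested. It differs from compound 3 by methyl in place of hydrogen on a saturated chain carbon, three bonds along the chain from an amide-type nitrogen and a carbonyl carbon. This is the same kind of change as that from compound 2 to compound 1, though the surroundings differ: there the carbon lies two bonds along the chain from a saturated ring carbon, here three bonds along the chain from an amide-type nitrogen and a carbonyl carbon. Among the measured compounds shown here, since the earlier step was unreadable and every compound so far only reaches a limit, compound 4 is expected to show a small step, a step that the limit leaves unreadable from compound 3 to compound 4, and is estimated at 250 ug/mL, most probably once more reported as a limit.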

Compound 4, minimum cytotoxic concentration: >= 80 ug/mL
Compound 4: a limit, no number (the forecaster's own chance of this, stated with the estimate: 85%); the middle value does not contradict the limit.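

Among the compounds shown here, the result for compound 4 in this assay is a limit, as is that of compound 3, so no step between compound 3 and compound 4 can be read. The compounds shown leave open at what concentration any of them becomes cytotoxic, and whether methyl in place of hydrogen changes tolerance at all.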